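Amide swap on the shared core: hydroxypiperidine to pyrrolidine

This account rests on a few compounds, and the source may have more. Where it says the series, first, only, none or still open, it means among the compounds named here.

Compound 2 `N#CC1(NC(=O)[C@@H]2C[C@@H](S(=O)(=O)c3ccccc3)C[C@H]2C(=O)N2CCC(O)CC2)CC1` gives 1 nM in an assay on isolated protein for inhibition of cathepsin S (Homo sapiens), read by fluorescence, with a stated time of 20 min (a lower number here means a stronger inhibitor, a higher number a weaker inhibitor), and holds the higher of the two numbers; compound 1 `C[C@@H]1CN(C(=O)[C@@H]2C[C@H](S(=O)(=O)c3ccccc3)C[C@H]2C(=O)NC2(C#N)CC2)C[C@H](C)O1` gives 0.4 nM. For the measured compounds named here, the one measured step at this position, a 2.5-fold higher number from compound 1 to compound 2 (0.40 log units; beyond the scatter), is modest. Compound 3 `N#CC1(NC(=O)[C@@H]2C[C@@H](S(=O)(=O)c3ccccc3)C[C@H]2C(=O)N2CCCC2)CC1` changes the same position: pyrrolidin-1-yl in place of 4-hydroxypiperidin-1-yl on a carbonyl carbon. Both measured amide variants lie close together, so compound 3 is expected to move little, with no change at the digits printed from compound 2 to compound 3 (within the scatter) not beyond the scatter in either direction. Compound 3 is therefore estimated at 1 nM, within 0.3 nM to 4 nM.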

Compound 3, half-maximal inhibitory concentration: 2 nM
Estimate against measurement, compound 3: 2.0-fold (0.30 log units) below; the range from low to high includes it.
By their numbers in this assay, from the lowest: compound 1; then compounds 2 and 3 (each within the scatter of the next).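

At this position on the carbonyl carbon, this assay gives a 2.0-fold higher number from compound 2 to compound 3 (0.30 log units; within the scatter), so pyrrolidin-1-yl, with no hydrogen-bond donor or acceptor, cannot be told apart from 4-hydroxypiperidin-1-yl. Against 2,6-dimethylmorpholin-4-yl, the same group gives a 5.0-fold higher number from compound 1 to compound 3 (0.70 log units; beyond the scatter), the widest step yet at this position, though still modest. No available evidence accounts for these steps.

Still open, from the compounds shown here alone, is whether an open-chain dimethylamino group or a piperazin-1-yl ring on the same carbonyl carbon would stay within this narrow range.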